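Swapping methyl for ethynyl on compound 3

The compounds below may be only part of what the source reports. "The series", "measured", "known", "first", "only" and "open" are said of these compounds alone.

Compound 1 `COc1ccccc1N1C(=O)CSC1c1cc(F)cc(C(=O)NCCCCc2ccccc2)c1` gives 3260 mL.min-1.g-1
Compound 2 `C#Cc1cc(C(=O)NCCCCc2ccccc2)cc(C2SCC(=O)N2c2ccccc2OC)c1` gives 2200 mL.min-1.g-1
Compound 3 `Cc1cccc(N2C(=O)CSC2c2cccc(C(=O)NCCCCc3ccccc3)c2)c1` gives 3140 mL.min-1.g-1

These numbers come from an ADME assay on microsomes from liver (Rattus norvegicus) for metabolic stability, read by LC-MS, using NADPH, with a stated time of 10 min, tested at 0.1 uM (a higher number here means faster removal of the compound, a lower number slower removal), and all lie within the usual scatter of one another, so compound 3 at 3140 mL.min-1.g-1 is not set apart from the other two. The next molecule is compound 4 `C#Cc1cccc(N2C(=O)CSC2c2cccc(C(=O)NCCCCc3ccccc3)c2)c1`, which has not yet been measured. The change from compound 3 is ethynyl in place of methyl on an aromatic carbon and amounts to ethynyl in place of methyl on an aromatic carbon, turning 3-methylphenyl into 3-ethynylphenyl.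

Going by the values given here, only one measured step brings in ethynyl, namely a 1.5-fold lower number from compound 1 to compound 2 (0.17 log units; within the scatter), and it stays within the scatter. That step replaces fluoro rather than methyl, and on a different ring. Among the compounds with values here, no measured pair makes the methyl-to-ethynyl swap directly, so the guide is a weak one. Within the data shown here, with a 1.5-fold lower number from compound 1 to compound 2 (0.17 log units; within the scatter) as the only evidence, no change beyond the scatter is expected in this assay, with at most a slight lean towards a lower number. The estimated step is a 1.2-fold lower number from compound 3 to compound 4 (0.08 log units; within the scatter) and would lie within the scatter. Compound 4 is expected at 2600 mL.min-1.g-1 with 1500 mL.min-1.g-1 to 4300 mL.min-1.g-1 as its likely range.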

Compound 4, intrinsic clearance in microsomes: 1820 mL.min-1.g-1
Compound 4: the middle estimate sits 1.4-fold (0.15 log units) above what was measured; the measured number falls inside the stated range.
By their numbers in this assay, from the lowest: compounds 4, 2, 3 and 1 (each within the scatter of the next).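

In this assay, going by these compounds alone, exchanging 3-methylphenyl for 3-ethynylphenyl gives a 1.7-fold lower number from compound 3 to compound 4 (0.24 log units; within the scatter), the first direct reading of this swap on an aromatic carbon of a six-membered aromatic ring of carbon only, meta to a large group. The earlier ethynyl step, a 1.5-fold lower number from compound 1 to compound 2 (0.17 log units; within the scatter), replaced fluoro on a different ring, so ethynyl has now been read at two places, and at neither does the step go beyond the usual scatter of repeated measurements. No supporting measurement is available to explain this step.

The compounds shown leave open how a nitrile, an amine or a carboxylic acid at this same place would read in this assay, and whether any group there would produce a step clearly beyond the scatter. Also open, from the compounds shown here alone, is whether ethynyl would give a similar reading if the chain on the amide were shorter, since every compound here carries the same chain and a single pair cannot show how far this result extends.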